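Chain extension from compound 1 to compound 3: working notes

A few compounds are considered here, and "the series" means these few. Any claim that something is new, unique, unknown or untested is made for them only; others in the source may bear on it.

Compound 1 `CCCCCNc1nccnc1C(=O)NCc1ccccc1` carries a saturated chain on a nitrogen on an aromatic ring. In an ADME assay on HEL cells (Homo sapiens) for cytotoxicity, read by microscopy, with a stated time of 6 days (a lower number here means that less compound is tolerated, a higher number that more compound is tolerated), compound 1 gives >= 100000 nM, which is a limit of the assay rather than a number. Compound 1 therefore stands at the limit of >= 100000 nM in this assay, at which 1 of the 2 values shown sits. Compound 2 `O=C(NCc1ccccc1)c1cnc(Cl)cn1` has in this assay the entry "not determined" (no result reported), so no number is available for it. Compound 3 `CCCCCCNc1nccnc1C(=O)NCc1ccccc1` is the next chain homologue of compound 1, and the difference is methyl in place of hydrogen on a saturated chain carbon, five bonds along the chain from a nitrogen on an aromatic ring. Within the data shown here, no measured pair in this set shows the effect of such a change, so the expectation for compound 3 rests on compound 1 alone. One added chain carbon is not expected to move the minimum cytotoxic concentration beyond the usual scatter. The step of a number no higher from compound 1 to compound 3 (the limit leaves the size open) is expected to be essentially flat. Compound 3 is accordingly estimated at 100000 nM in this assay, with a range of 50000 nM to 200000 nM. Given that compound 1 reports only a limit, compound 3 is expected to return a limit as well rather than a defined value.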

Compound 3, minimum cytotoxic concentration: 100000 nM
Beside the measured number, compound 3's estimate shows no gap at the digits printed; measured number inside the range.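

In this assay, among these compounds, compound 3 gives 100000 nM, the first defined number for this saturated chain. The earlier compounds shown here offered only a limit and an entry without a result. Methyl in place of hydrogen on a saturated chain carbon, five bonds along the chain from a nitrogen on an aromatic ring, gives a number no higher from compound 1 to compound 3 (the limit leaves the size open), so the direction of the comparison is bounded but the size of the change cannot be read. Compound 1 remains a limit of the assay rather than a number, which leaves the comparison with one open end: the limit of >= 100000 nM in this assay, at which 1 of the 3 values shown sits.

The compounds shown leave open whether a longer chain, or a chain ending in an amine or a carboxylic acid, would give a minimum cytotoxic concentration clearly different from that of compound 3. They also leave open how far the reading depends on the chain itself, as opposed to the core of compound 1, which is unchanged in this pair.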